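Removing one methoxy group from a compound without measurable cytotoxicity

The source may hold more compounds than are shown below. What is called first, only, known or untested is meant among the compounds shown, and "the series" means these compounds.

Compound 1, `COc1ccc(C2=C(c3cc(OC)c(OC)c(OC)c3)C(=O)CC2O[SiH2]C(C)(C)C)cc1OC`: in an ADME assay on ECV-304 cells (Homo sapiens) for cytotoxicity, read by MTT assay, with a stated time of 72 h (a higher number here means a weaker inhibitor, a lower number a stronger inhibitor), compound 1 gives > 100 ug/mL, which is a limit of the assay and not a number.
Compound 2, `COc1ccc(C2=C(c3cc(OC)c(OC)c(OC)c3)C(=O)C(OC(C)=O)C2)cc1OC(C)C`: in this assay compound 2 gives > 100 ug/mL, again a limit rather than a number.
Compound 3, `COc1cc(C2=C(c3cc(C)c(OC)c(C)c3)C(OC(C)=O)CC2=O)cc(OC)c1OC`: in this assay compound 3 gives > 100 ug/mL, once more only a limit.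

Compound 1 therefore has no exact value of its own in this assay; it stands at the boundary of what the assay reports, and so do the two companions, as noted in the limit of > 100 ug/mL in this assay, at which 3 of the 3 values shown sit. Going by the values given here, no step between two measured compounds can be drawn from these values, since none of them is a number.

Compound 4, `COc1ccc(C2=C(c3cc(OC)c(OC)c(OC)c3)C(=O)CC2O[SiH2]C(C)(C)C)cc1`, has not yet been measured in this assay. It differs from compound 1 in one place: hydrogen in place of methoxy on an aromatic carbon.

Among the compounds with values here, with every measured compound sitting at the same limit, no step is on record that would show the size or direction of such a change, so the expected step from compound 1 to compound 4 in this assay is estimated as none beyond the scatter, a step that the limit leaves unreadable from compound 1 to compound 4. Compound 4 is accordingly expected to give about 150 ug/mL in this assay, estimated to lie between 60 ug/mL and 400 ug/mL, most likely reported again only as a limit.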

Compound 4, half-maximal inhibitory concentration: > 100 ug/mL
Compound 4: no number, only a limit; the forecaster's own chance of this, stated with the estimate: 80%; the middle value is on the limit's open side.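

Compound 1 and compound 4 both stand only at a limit in this assay, so no step can be read for hydrogen in place of methoxy on an aromatic carbon: the limit of > 100 ug/mL in this assay, at which 4 of the 4 values shown sit.

The compounds shown leave open how large any difference between compound 1 and compound 4 is, and which change to the shared core, if any, would give a measurable value in this assay.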